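Chalcone-linked imidazolones against colon carcinoma cells

A few compounds are considered here, and "the series" means these few. Any claim that something is new, unique, unknown or untested is made for them only; others in the source may bear on it.

Measured compounds:
compound 1 `O=C(/C=C/c1cccc(O)c1)c1cccc(-n2cc(-c3ccccc3)[nH]c2=O)c1` gives 3020 nM
compound 2 `O=C(/C=C/c1cccc(O)c1)c1cccc(-n2cc(-c3ccc(Cl)cc3)[nH]c2=O)c1` gives 1230 nM
compound 3 `COc1cc(/C=C/C(=O)c2cccc(-n3cc(-c4ccccc4)[nH]c3=O)c2)cc(OC)c1OC` gives 330 nM

In a functional assay on HCT-116 cells (Homo sapiens) for inhibition (on this read-out lower numbers stand for stronger inhibition of growth and higher numbers for weaker inhibition of growth), compound 2 stands second highest of the three numbers, between compound 1 and compound 3. Within the data shown here, the one counted step, a 2.5-fold lower number from compound 1 to compound 2 (0.39 log units; beyond the scatter), concerns the chloro group and does not touch the ring that changes here. Compound 4 `COc1cc(/C=C/C(=O)c2cccc(-n3cc(-c4ccc(Cl)cc4)[nH]c3=O)c2)ccc1O` differs from compound 2 in this way: 4-hydroxy-3-methoxyphenyl in place of 3-hydroxyphenyl on a double-bonded chain carbon bound to a double-bonded chain carbon. Among the measured compounds shown here, no measured step bears on that change directly; only compound 1 and compound 3, which carry different rings in that place, show that the ring on the chain can move the number well beyond the scatter. Compound 4 is therefore expected to give about 700 nM, within 250 nM to 2000 nM. That estimate means a step of a 1.8-fold lower number from compound 2 to compound 4 (0.24 log units; within the scatter) is expected.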

Compound 4, concentration for 50% growth inhibition: 1460 nM
Compound 4: the middle estimate sits 2.1-fold (0.32 log units) below what was measured, and the stated range covers the measured number.
By their numbers in this assay, from the lowest: compound 3; then compounds 2 and 4 (each within the scatter of the next); then compound 1.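

In this assay, replacing 3-hydroxyphenyl with 4-hydroxy-3-methoxyphenyl on a double-bonded chain carbon bound to a double-bonded chain carbon gives a 1.2-fold higher number from compound 2 to compound 4 (0.07 log units; within the scatter). The earlier compounds shown here showed that a ring exchange at this position can move the number beyond the scatter, whereas this exchange, made with the chloro group present, does not. Nothing available explains this result. On these data alone, it remains open whether the ring of compound 3 would keep its value alongside the chloro group. Also open, as far as these compounds go, is how an amine or a carboxylic acid on this ring would read.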